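Methoxy to fluoro: what to expect of compound 4

A few compounds are considered here, and "the series" means these few. Any claim that something is new, unique, unknown or untested is made for them only; others in the source may bear on it.

compound 1 `CC(=O)N1N=C(c2ccc3ccccc3c2)OC1c1ccccc1`: 2.11 ug/mL
compound 2 `COc1ccc(C2OC(c3ccc4ccccc4c3)=NN2C(C)=O)cc1`: 3.6 ug/mL
compound 3 `CC(=O)N1N=C(c2ccc3ccccc3c2)OC1c1cccc(F)c1`: 1.86 ug/mL

In a functional assay on HepG2 cells (Homo sapiens) for antiproliferative activity, read by MTT assay, with a stated time of 48 h (on this read-out lower numbers stand for stronger inhibition and higher numbers for weaker inhibition), compound 2 lies within the scatter of both other compounds, so no order among the three can be claimed. Compared with compound 2, the unmeasured compound 4 `CC(=O)N1N=C(c2ccc3ccccc3c2)OC1c1ccc(F)cc1` has fluoro in place of methoxy on an aromatic carbon. For the measured compounds named here, three measured steps bear on this. Methoxy in place of hydrogen gave a 1.7-fold higher number from compound 1 to compound 2 (0.23 log units; within the scatter) and fluoro in place of hydrogen gave a 1.1-fold lower number from compound 1 to compound 3 (0.05 log units; within the scatter) while the swap to 3-fluorophenyl, not the 4-fluorophenyl of compound 4, gave a 1.9-fold lower number from compound 2 to compound 3 (0.29 log units; within the scatter) as the closest case. All three stay within the scatter. The expected step in this assay is a 1.7-fold lower number from compound 2 to compound 4 (0.23 log units; within the scatter) and is a small move toward a lower number, with none beyond the scatter. The estimate for compound 4 is 2.1 ug/mL with an expected range of 1.2 ug/mL to 3.7 ug/mL when measured.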

Compound 4, half-maximal inhibitory concentration: 1.82 ug/mL
Estimate against measurement, compound 4: 1.2-fold (0.06 log units) above, within the range that was stated.
By their numbers in this assay, from the lowest: compounds 4, 3, 1 and 2 (each within the scatter of the next).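

In this assay, fluoro in place of methoxy, para to a large group, gives a 2.0-fold lower number from compound 2 to compound 4 (0.30 log units; within the scatter), so even this direct swap of the two groups does not leave the scatter. Moving from 3-fluorophenyl to 4-fluorophenyl gives a 1.0-fold lower number from compound 3 to compound 4 (0.01 log units; within the scatter), and fluoro in place of hydrogen gives a 1.2-fold lower number from compound 1 to compound 4 (0.06 log units; within the scatter), so neither the place of the fluoro nor its presence separates these compounds. Nothing at hand explains why these steps are so small.

The compounds shown leave open whether an amine or a carboxylic acid at this position would move the number beyond the scatter.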